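Indole N-methylation on the indol-3-yl amide: compound 4 outlook

The source may report more compounds than this note shows. Statements on the series, on what has been measured and on what is new or still open speak of the compounds shown alone.

Measured so far in a functional assay on HEK293 cells for positive allosteric modulation of metabotropic glutamate receptor 5 (Homo sapiens), read by calcium flux; a lower number here means a smaller maximal response, a higher number a larger maximal response:
compound 1 `O=C(c1cc2ccccc2[nH]1)N1CCc2nc(COc3ccccc3)oc2C1` gives 40%
compound 2 `Cn1c(C(=O)N2CCc3nc(COc4ccccc4)oc3C2)cc2ccccc21` gives 57%
compound 3 `O=C(c1c[nH]c2ccccc12)N1CCc2nc(COc3ccccc3)oc2C1` gives 71%

Compound 3 stands highest of the three; the step of a number 31 percentage points higher from compound 1 to compound 3 (beyond the scatter) is large, and compound 2 lies closer to it. The next compound, compound 4 `Cn1cc(C(=O)N2CCc3nc(COc4ccccc4)oc3C2)c2ccccc21`, carries methyl in place of hydrogen on an aromatic nitrogen. Among the measured compounds shown here, the one step that bears on this change is a number 17 percentage points higher from compound 1 to compound 2 (beyond the scatter), which was modest but beyond the scatter. Carrying that size of step over from compound 3, a modest rise in this assay is expected for compound 4, with the caveat that only one such step is available and it was made on the indol-2-yl amide. The expected step is a number 14 percentage points higher from compound 3 to compound 4 (beyond the scatter). For compound 4 the estimate is 85%, within 68% to 102%.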

Compound 4, largest response reached (reported as percent of maximum), in percent of the reference or control that the assay uses: 70%
The estimate for compound 4 lay 15 percentage points above the measured number; the range from low to high includes it.
By their numbers in this assay, from the lowest: compound 1; then compound 2; then compounds 4 and 3 (each within the scatter of the next).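

In this assay, methyl in place of hydrogen on the aromatic nitrogen gives a step within the scatter on the indol-3-yl amide: a number 1 percentage points lower from compound 3 to compound 4 (within the scatter). On this amide, the hydrogen on that nitrogen is therefore not required for a high maximal response. The same change does not give one transferable step across the two cores: the same change on two cores in this assay, a number 17 percentage points higher (beyond the scatter) from compound 1 to compound 2 and a number 1 percentage points lower (within the scatter) from compound 3 to compound 4, 18 percentage points apart, beyond the scatter of two such steps

From the compounds shown here alone, whether an ethyl group, a longer chain or a chain ending in a carboxylic acid on this nitrogen would keep the response stays open. Among the compounds shown here, with only two pairs, how the step varies on other cores also stays open.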